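The compounds below may be only part of what the source reports. "The series", "measured", "known", "first", "only" and "open" are said of these compounds alone.

Compound 1 `COc1cccc2c1CCC2c1ncc[nH]1`: > 10000 nM
Compound 2 `CNC(=O)c1cccc2c1CCC2c1ncc[nH]1`: > 10000 nM

In a functional assay on CHO cells for agonist activity at Alpha-1B adrenergic receptor (Homo sapiens), read by FLIPR and calcium flux (on this read-out lower numbers stand for an effect already at smaller amounts and higher numbers for an effect only at larger amounts of compound), compound 1 gives > 10000 nM, which is a limit of the assay rather than a number. Compound 2 gives > 10000 nM, also a limit. For the measured compounds named here, the only measured step, a step that the two limits leave unreadable from compound 1 to compound 2, therefore has no readable size (the limit of > 10000 nM in this assay, at which 2 of the 2 values shown sit). Compound 3 `COc1c(Cl)ccc2c1CCC2c1ncc[nH]1` differs from compound 1 by chloro in place of hydrogen on an aromatic carbon. Going by the values given here, no measured step touches a chloro, so the expectation rests on compound 1 alone. Compound 3 is expected to remain near that limit, at about 15000 nM, within 5000 nM to 50000 nM. This means an expected step that the limit leaves unreadable from compound 1 to compound 3.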

Compound 3, half-maximal effective concentration: > 10000 nM
Compound 3: only a limit was reported (the forecaster's own chance of this, stated with the estimate: 80%); the middle value is on the limit's open side.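

Compound 1 and compound 3 both give only a limit in this assay, so the step between them cannot be read: the limit of > 10000 nM in this assay, at which 3 of the 3 values shown sit.

The compounds shown leave open whether chloro or methylcarbamoyl on the shared core changes the effect at all.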